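A few compounds are considered here, and "the series" means these few. Any claim that something is new, unique, unknown or untested is made for them only; others in the source may bear on it.

Measured so far in a functional assay on HCT-116 cells (Homo sapiens) for cytotoxicity, read by MTT assay, with a stated time of 72 h; a lower number here means a stronger inhibitor, a higher number a weaker inhibitor:
compound 1 `N[C@H]1CC[C@H](Nc2c(C(=O)NCc3ccc(F)cc3)nc(Br)c3cccnc23)CC1`: 7000 nM
compound 2 `N[C@H]1CC[C@H](Nc2c(C(=O)NCc3ccc(Cl)cc3)nc(Br)c3cccnc23)CC1`: 4000 nM
compound 3 `N[C@H]1CC[C@H](Nc2c(C(=O)NCc3ccccn3)nc(Br)c3cccnc23)CC1`: "not determined" (no result reported)

Compound 1 shares its place on this short scale with compound 2, as the two numbers lie within the scatter of each other: a 1.8-fold lower number from compound 1 to compound 2 (0.24 log units; within the scatter). For the measured compounds named here, compound 3 supplies no number for comparison, so the series offers only this one measured step.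

The next compound is compound 4 `Cc1ccc(S(=O)(=O)Oc2c(C(=O)NCc3ccc(F)cc3)nc(Br)c3cccnc23)cc1`, which differs from compound 1 at a single place: ((4-methylphenyl)sulfonyl)oxy in place of (4-aminocyclohexyl)amino on an aromatic carbon. The incoming ((4-methylphenyl)sulfonyl)oxy stands where (4-aminocyclohexyl)amino stood, para to a bromo group.

The measured step gives little guidance here. a 1.8-fold lower number from compound 1 to compound 2 (0.24 log units; within the scatter) puts chloro in place of fluoro on an aromatic carbon and leaves the (4-aminocyclohexyl)amino untouched. Going by the values given here, no measured compound carries any other group at the place that changes, so neither the size nor the direction of the new step can be read from the data. A modest move towards a higher number is expected, held only loosely, and a result reported only as a limit is possible. The estimate amounts to an expected 1.7-fold higher number from compound 1 to compound 4 (0.23 log units; within the scatter). For compound 4 the estimated value is 12000 nM, with an expected range of 3000 nM to 50000 nM.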

Compound 4, half-maximal inhibitory concentration: > 20000 nM
Compound 4 ended at the assay's limit; the forecaster's own chance of this, stated with the estimate: 40%; middle value at least 1.6-fold (0.22 log units) away from the limit.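

Unlike the chloro for fluoro exchange, which stayed within the scatter, the change at this position moves the result beyond it: in this assay, ((4-methylphenyl)sulfonyl)oxy in place of (4-aminocyclohexyl)amino gives an at least 2.8-fold higher number from compound 1 to compound 4 (0.45 log units; beyond the scatter). This shows that the group para to the bromo group has a clear bearing on the read-out, with the sulfonyloxy compound the weaker of the pair. Compound 4 is reported only as a limit of the assay, so the step fixes a minimum and not a size: the limit of > 20000 nM in this assay, at which 1 of the 4 values shown sits.

The exchange also replaces a six-membered non-aromatic ring of carbon only with an aromatic one, removes both nitrogens and both hydrogen-bond donors, and adds a sulfur and three oxygens, so these two compounds cannot show which of these differences counts. A plain amino group, an open-chain aminoalkylamino group or a cyclohexylamino group without the terminal amine at this place would be needed to separate the contribution of the ring from that of the amine.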